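The source may hold more compounds than are shown below. What is called first, only, known or untested is meant among the compounds shown, and "the series" means these compounds.

Notes on the series. Three analogues sharing one core have been measured in a physicochemical assay for lipophilicity, in phosphate buffer, measured as octanol-water partition, with a stated time of 24 h; on this read-out lower numbers stand for lower lipophilicity and higher numbers for higher lipophilicity. Compound 1 `CN(C)c1ccc(C2SCC(=O)N2NC(=O)CN2C(=O)c3ccccc3C2=O)cc1` gives 2.84 in this assay; compound 2 `O=C(CN1C(=O)c2ccccc2C1=O)NN1C(=O)CSC1c1ccc(O)cc1` gives 2.4; compound 3 `O=C(CN1C(=O)c2ccccc2C1=O)NN1C(=O)CSC1c1ccc(Cl)cc1` gives 3.21. Compound 3 stands highest of the three: the step of a number 0.37 log units higher from compound 1 to compound 3 (beyond the scatter) carries a chloro in place of dimethylamino on an aromatic carbon, the step of a number 0.81 log units higher from compound 2 to compound 3 (beyond the scatter) a chloro in place of hydroxy on the same carbon, and the step of a number 0.44 log units lower from compound 1 to compound 2 (beyond the scatter) a hydroxy in place of dimethylamino.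

Compound 4 `O=C(CN1C(=O)c2ccccc2C1=O)NN1C(=O)CSC1c1ccc(Cl)cc1Cl` is not yet measured. Against compound 3 it shows (chloro in place of hydrogen on an aromatic carbon), placed on an aromatic carbon of a six-membered aromatic ring of carbon only, ortho to a large group and meta to a chloro group; cut one bond further out, the change reads 4-chlorophenyl to 2,4-dichlorophenyl. None of the three measured steps exchanges a hydrogen for chloro, so they bear only loosely on it; the two steps that bring chloro in, a number 0.37 log units higher from compound 1 to compound 3 (beyond the scatter) and a number 0.81 log units higher from compound 2 to compound 3 (beyond the scatter), both run upward and beyond the scatter. A further upward step of similar or somewhat smaller size is therefore expected: the estimate for compound 4 is 3.8 in this assay, within 3.4 to 4.2, meaning an expected step of a number 0.59 log units higher from compound 3 to compound 4 (beyond the scatter).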

Compound 4, partition coefficient: 2.54
The estimate for compound 4 lay 1.26 log units above the measured number; the whole stated range lies above it.
By their numbers in this assay, from the lowest: compounds 2, 4 and 1 (each within the scatter of the next, the first and the last beyond it); then compound 3.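

On an aromatic carbon ortho to a large group and meta to a chloro group, chloro in place of hydrogen gives a downward move, a number 0.67 log units lower from compound 3 to compound 4 (beyond the scatter), so the upward direction of the two earlier steps that bring chloro in, both exchanges for another group rather than for hydrogen, does not carry over to this change. In this assay the second chloro removes the separation that compound 3 held from the other analogues: the 2,4-dichlorophenyl group gives a number 0.14 log units higher from compound 2 to compound 4 (within the scatter) against the 4-hydroxyphenyl group and a number 0.30 log units lower from compound 1 to compound 4 (within the scatter) against the 4-(dimethylamino)phenyl group, so compound 4 cannot be ordered against either. No measurement at hand accounts for the downward step, and it stands here as an observation only.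

The compounds shown hold a single group at this place, so it stays open whether the downward step belongs to chloro or to any group on this carbon, which a fluoro, methyl or methoxy group there would help to separate. Also open, on these data alone, is whether the step needs the chloro already present in compound 3, which a phenyl ring with chloro on this carbon alone would test.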